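Carboxylic acid series: moving the acid and methylating the amine

The source may report more compounds than this note shows. Statements on the series, on what has been measured and on what is new or still open speak of the compounds shown alone.

Compound 3 `CC(C)c1onc(-c2c(Cl)cccc2Cl)c1COc1ccc(NCc2ccc(C(=O)O)cc2)c(C(F)(F)F)n1` sits at the lowest number of the three compounds measured in an assay on isolated protein for agonist activity at Bile acid receptor (Homo sapiens), read by FRET (a higher number here means that more compound is needed for the effect, a lower number that less compound is needed), where compound 3 gives 162 nM. Compound 1 `CC(C)c1onc(-c2c(Cl)cccc2Cl)c1COc1ccc(N(C)C(=O)c2ccc(C(=O)O)cc2)c(C(F)(F)F)n1` gives 235 nM in this assay, which lies within the scatter of compound 3, so no order between them is claimed; compound 2 `CC(C)c1onc(-c2c(Cl)cccc2Cl)c1COc1ccc(NC(=O)c2ccc(C(=O)O)cc2)c(C(F)(F)F)n1` gives 452 nM, a separation that is beyond the scatter, as seen in a 2.8-fold lower number from compound 2 to compound 3 (0.45 log units; beyond the scatter).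

Compound 4 `CC(C)c1onc(-c2c(Cl)cccc2Cl)c1COc1ccc(N(C)Cc2cccc(C(=O)O)c2)c(C(F)(F)F)n1` differs from compound 3 by (3-carboxybenzyl)(methyl)amino in place of (4-carboxybenzyl)amino on an aromatic carbon, at a position on an aromatic carbon of a six-membered aromatic ring with one nitrogen, ortho to a trifluoromethyl group and para to a large group.

Of the measured steps, only a 1.9-fold higher number from compound 1 to compound 2 (0.28 log units; within the scatter) touches a methyl on a nitrogen, and it stayed within the scatter, though on an amide-type nitrogen rather than on the amine of compound 4. Within the data shown here, no measured pair addresses moving the carboxylic acid from the 4-position to the 3-position of the benzyl ring, so that part of the change is untested. The step is therefore expected to be small, a 1.6-fold higher number from compound 3 to compound 4 (0.21 log units; within the scatter), with wide uncertainty from the untested acid position. Compound 4 is estimated at 260 nM, in a range from 80 nM to 850 nM.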

Compound 4, half-maximal effective concentration: 12 nM
Beside the measured number, compound 4's estimate is 22-fold (1.34 log units) above it, outside the stated range (below it).
By their numbers in this assay, from the lowest: compound 4; then compounds 3, 1 and 2 (each within the scatter of the next, the first and the last beyond it).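

Notes on the group at the aromatic carbon ortho to a trifluoromethyl group: in this assay this place proves far more responsive than the earlier compounds showed, with (3-carboxybenzyl)(methyl)amino in place of (4-carboxybenzyl)amino giving a large step (a 14-fold lower number from compound 3 to compound 4 (1.13 log units; beyond the scatter)), against a modest one as the largest earlier step (a 2.8-fold lower number from compound 2 to compound 3 (0.45 log units; beyond the scatter)). The two amide compounds also stand well apart from compound 4 (a 38-fold lower number from compound 2 to compound 4 (1.58 log units; beyond the scatter); a 20-fold lower number from compound 1 to compound 4 (1.29 log units; beyond the scatter)), which leaves compound 4 the most potent of the four, with all its steps beyond the scatter. Nothing at hand bears on what lies behind this gain.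

The compounds shown hold neither change alone, so the share of the moved acid and the share of the methyl on the nitrogen stay unresolved. Also open, on these data alone, is how a 2-carboxybenzyl group, or an ethyl on that nitrogen, would read.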